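The compounds below may be only part of what the source reports. "The series", "measured", "known", "first", "only" and "open" are said of these compounds alone.

Compound 1 `CCn1ccnc1/C=C/C(=O)/C=C/c1coc2ccccc2c1=O` reads 1800 nM in a functional assay on PC-3 cells (Homo sapiens) for cytotoxicity, read by WST assay, with a stated time of 3 days (a lower number here means a stronger inhibitor, a higher number a weaker inhibitor), and compound 2 `CC(C)n1ccnc1/C=C/C(=O)/C=C/c1coc2ccccc2c1=O` reads 2300 nM there, while compound 3 `CC(C)CCn1ccnc1/C=C/C(=O)/C=C/c1coc2ccccc2c1=O` reads 3600 nM on the same scale. Compound 3 therefore stands within the scatter of both other compounds (a 2.0-fold higher number from compound 1 to compound 3 (0.30 log units; within the scatter) and a 1.6-fold higher number from compound 2 to compound 3 (0.19 log units; within the scatter)). Compound 4 `CCC(CC)n1ccnc1/C=C/C(=O)/C=C/c1coc2ccccc2c1=O` differs from compound 3 by one change (pentan-3-yl in place of isopentyl on an aromatic nitrogen), pentan-3-yl in place of isopentyl on an aromatic nitrogen. The remaining measured step on this nitrogen (a 1.3-fold higher number from compound 1 to compound 2 (0.11 log units; within the scatter)) also stays within the scatter, so no step beyond the scatter is expected in this assay here, and no direction can be called. The expected change is small (a 1.3-fold lower number from compound 3 to compound 4 (0.12 log units; within the scatter)). For compound 4 the estimate is 2700 nM with an expected range from 1300 nM to 5400 nM in this series.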

Compound 4, half-maximal inhibitory concentration: 2900 nM
Estimate against measurement, compound 4: 1.1-fold (0.03 log units) below; measured number inside the range.
By their numbers in this assay, from the lowest: compounds 1, 2, 4 and 3 (each within the scatter of the next).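

Rearranging the same five carbons from isopentyl to pentan-3-yl on the aromatic nitrogen stays within the scatter in this assay (a 1.2-fold lower number from compound 3 to compound 4 (0.09 log units; within the scatter)). Pentan-3-yl also stays within the scatter of isopropyl (a 1.3-fold higher number from compound 2 to compound 4 (0.10 log units; within the scatter)) and of ethyl (a 1.6-fold higher number from compound 1 to compound 4 (0.21 log units; within the scatter)), so across these four compounds neither the shape nor the length of the alkyl group separates the numbers. No evidence bears on why these numbers lie so close together.

On these data alone, whether a benzyl group or a chain ending in an amine on this nitrogen would move the number beyond the scatter stays open.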